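This account rests on a few compounds, and the source may have more. Where it says the series, first, only, none or still open, it means among the compounds named here.

Of the compounds shown here, three of a shared core have been measured in a functional assay on HCT-116 cells (Homo sapiens) for inhibition, read by MTT assay, with a stated time of 24 h, tested at 5 uM; a higher number here means more inhibition of growth at the concentration tested, a lower number less inhibition of growth. Compound 1 `CS(=O)(=O)c1ccc(-c2cnc3[nH]cc(-c4nnc(-c5ccncc5)o4)c(=O)c3c2)cc1` gives 5.61% in this assay. Compound 2 `CS(=O)(=O)c1ccc(-c2cnc3[nH]cc(-c4nnc(-c5ccccc5)o4)c(=O)c3c2)cc1` carries a phenyl where compound 1 carries a pyridin-4-yl; in this assay compound 2 gives 8.6%. Compound 3 `O=c1c(-c2nnc(-c3ccc(F)cc3)o2)c[nH]c2ncc(-c3cccnc3)cc12` differs from both in several places; in this assay compound 3 gives 11.1%. Among these three numbers compound 2 stands second highest, with compound 3 nearest and compound 1 furthest, and both of those gaps lie within the usual scatter of the measurement. Within the data shown here, the one step between neighbours that differ in a single place is a number 3 percentage points higher from compound 1 to compound 2 (within the scatter), so the exchange of pyridin-4-yl for phenyl left the growth inhibition essentially unchanged.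

Compound 4 `CS(=O)(=O)c1ccc(-c2cnc3[nH]cc(-c4nnc(-c5ccc(Cl)cc5)o4)c(=O)c3c2)cc1` is not yet measured. It differs from compound 2 by chloro in place of hydrogen on an aromatic carbon. Among the measured compounds shown here, no measured pair bears directly on a chloro entering in place of hydrogen; the only step on record, from compound 1 to compound 2, concerned a different part of the same aromatic ring and stayed within the scatter. On that basis the step from compound 2 to compound 4 is expected to be a number 1.4 percentage points higher from compound 2 to compound 4 (within the scatter), that is, nothing beyond the scatter. Compound 4 is therefore estimated to give 10% in this assay, with a likely range from 0% to 25%.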

Compound 4, percent growth inhibition at one concentration: 16.4%
Compound 4: middle estimate off by 6.4 percentage points, on the low side; the range from low to high includes it.
By their numbers in this assay, from the lowest: compounds 1, 2, 3 and 4 (each within the scatter of the next, the first and the last beyond it).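

Compound 4 puts a chloro on the outer six-membered aromatic ring of carbon only, para to a large group, and in this assay the exchange of hydrogen for chloro gives a number 7.8 percentage points higher from compound 2 to compound 4 (within the scatter), so this single change cannot be told apart from no change at all. Among these compounds, the same ring now also yields the first step on record to pass the scatter: 4-chlorophenyl in place of pyridin-4-yl gives a number 10.8 percentage points higher from compound 1 to compound 4 (beyond the scatter), a modest step, whereas phenyl in place of pyridin-4-yl gave only a number 3 percentage points higher from compound 1 to compound 2 (within the scatter), so two exchanges on this ring that each stay within the scatter add up to one that does not. Nothing at hand offers an explanation for this result.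

On these data alone, compound 4 at 16.4% still shows only a small share of growth inhibition at the one concentration tested, and it remains open whether a methoxy, an amine or a carboxylic acid in place of the chloro would move the number beyond the scatter from compound 2. Among the compounds shown here, it also remains open whether the chloro would give a comparable step on a core that carries a group other than the one shared by compound 2 and compound 4.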